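This account rests on a few compounds, and the source may have more. Where it says the series, first, only, none or still open, it means among the compounds named here.

Working notes on the sulfated series. Compound 3 `CO[C@H]1O[C@H](CNC(=O)CN(C(C)=O)C2CCCCC2)[C@@H](OS(=O)(=O)O)[C@H](OS(=O)(=O)O)[C@@H]1OS(=O)(=O)O` gives 1700000 nM in an assay on isolated protein for binding affinity to vascular endothelial growth factor A, long form (Homo sapiens), read by surface plasmon resonance (on this read-out higher numbers stand for weaker binding and lower numbers for tighter binding), the highest number among the three measured compounds. Compound 1 `CO[C@H]1O[C@H](CNC(=O)CN(Cc2ccccc2)C(C)=O)[C@@H](OS(=O)(=O)O)[C@H](OS(=O)(=O)O)[C@@H]1OS(=O)(=O)O` gives 77000 nM in this assay, and compound 2 `CO[C@H]1O[C@H](CNC(=O)CN(C(C)=O)c2ccccc2)[C@@H](OS(=O)(=O)O)[C@H](OS(=O)(=O)O)[C@@H]1OS(=O)(=O)O` gives 76000 nM. The step of a 1.0-fold lower number from compound 1 to compound 2 (0.01 log units; within the scatter) lies within the scatter, whereas a 22-fold higher number from compound 1 to compound 3 (1.34 log units; beyond the scatter) and a 22-fold higher number from compound 2 to compound 3 (1.35 log units; beyond the scatter) are both large.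

Compound 4 `CCN(CC(=O)NC[C@H]1O[C@H](OC)[C@@H](OS(=O)(=O)O)[C@@H](OS(=O)(=O)O)[C@@H]1OS(=O)(=O)O)C(=O)CCCCC(=O)O` is not yet measured. Relative to compound 3 the change is ((4-carboxybutyl)carbonyl)(ethyl)amino in place of acetyl(cyclohexyl)amino on a saturated chain carbon bound to a carbonyl carbon. Within the data shown here, none of the measured steps covers this change directly; the only bearing is that the cyclohexyl group leaving in this step is the one whose arrival, in the steps from compound 1 and compound 2, brought the large rise in number. Among the measured compounds shown here, its removal is therefore expected to move the number downward, but the entering group has no precedent here, so the expected step is set smaller than those and with a wide range. For compound 4 the estimate is 300000 nM, between 60000 nM and 1500000 nM, meaning an expected step of a 5.7-fold lower number from compound 3 to compound 4 (0.75 log units; beyond the scatter).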

Compound 4, dissociation constant: 104000 nM
The estimate for compound 4 lay 2.9-fold (0.46 log units) above the measured number; the measured number falls inside the stated range.
By their numbers in this assay, from the lowest: compounds 2, 1 and 4 (each within the scatter of the next); then compound 3.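

In this assay, ((4-carboxybutyl)carbonyl)(ethyl)amino in place of acetyl(cyclohexyl)amino gives a 16-fold lower number from compound 3 to compound 4 (1.21 log units; beyond the scatter), so this position can reach the lower numbers of the series without any ring in the group. The entering group also stands level with acetyl(phenyl)amino, at a 1.4-fold higher number from compound 2 to compound 4 (0.14 log units; within the scatter), and with acetyl(benzyl)amino, at a 1.4-fold higher number from compound 1 to compound 4 (0.13 log units; within the scatter), which leaves compound 3 as the only one of the four apart from the others. Nothing at hand accounts for this result.

Both parts of the group change at once in this step, so the shares of the ethyl group and of the acid-bearing chain remain unseparated; acetyl(ethyl)amino would isolate the first. A longer chain ending in a carboxylic acid, or the same chain ending in an amine, would test whether the chain end matters at this position.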